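A few compounds are considered here, and "the series" means these few. Any claim that something is new, unique, unknown or untested is made for them only; others in the source may bear on it.

Compound 1 `COc1cccc(N2C(=O)COc3ccc(-c4cnc(Cl)c(NS(=O)(=O)c5ccc(F)cc5)c4)cc32)c1` gives in a functional assay on MCF7 cells (Homo sapiens) for antiproliferative activity, read by MTT assay, with a stated time of 72 h (on this read-out lower numbers stand for stronger inhibition and higher numbers for weaker inhibition), only the limit > 40000 nM.
Compound 2 `Cc1ccc(N2C(=O)COc3ccc(-c4cnc(Cl)c(NS(=O)(=O)c5ccc(F)cc5)c4)cc32)cc1` gives in this assay a value of 32600 nM.
Compound 3 `O=C1COc2ccc(-c3cnc(Cl)c(NS(=O)(=O)c4ccc(F)cc4)c3)cc2N1` gives in this assay only the limit > 40000 nM.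

Compound 3 stands at the limit of > 40000 nM in this assay, at which 2 of the 3 values shown sit, so its position on the numbers is known only as a limit, not as a number. Compound 4 `O=C1COc2ccc(-c3cnc(Cl)c(NS(=O)(=O)c4ccc(F)cc4)c3)cc2N1C1CC1` differs from compound 3 by cyclopropyl in place of hydrogen on an amide-type nitrogen in a ring. The measured steps that touch the same position are those in which an aryl group stands on the amide-type nitrogen instead of hydrogen: an at least 1.2-fold higher number from compound 2 to compound 3 (0.08 log units; that floor lies within the scatter) and a step that the two limits leave unreadable from compound 1 to compound 3. Neither of these shows a change that rises beyond the scatter; one is a floor within the scatter, the other cannot be read at all. Nothing in the measured steps therefore points to a step beyond the scatter in either direction in this assay when a small cyclopropyl replaces hydrogen at that position. Compound 4 is expected to sit near the limit again, with an estimated value of 40000 nM, somewhere between 20000 nM and 80000 nM. The step this estimate means for compound 4 is a number no higher from compound 3 to compound 4 (the limit leaves the size open), expected to stay within the scatter.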

Compound 4, half-maximal inhibitory concentration: 16700 nM
Compound 4: middle estimate off by 2.4-fold (0.38 log units), on the high side; measured number below the stated range.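

In this assay, among these compounds, cyclopropyl on the amide-type nitrogen in a ring gives an at least 2.3-fold lower number from compound 3 to compound 4 (0.37 log units; beyond the scatter), the first readable step at this position that lies beyond the scatter. The same holds for the replacement of 3-methoxyphenyl, with an at least 2.3-fold lower number from compound 1 to compound 4 (0.37 log units; beyond the scatter), whereas the replacement of 4-methylphenyl gives a 2.0-fold lower number from compound 2 to compound 4 (0.29 log units; within the scatter), so that compound 2 and compound 4 cannot be told apart. The first two steps are floors whose full size remains unknown, as compound 1 and compound 3 are known only as limits: the limit of > 40000 nM in this assay, at which 2 of the 4 values shown sit.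

The compounds shown leave open whether an open chain such as ethyl, or a larger ring such as cyclohexyl, would act like cyclopropyl at this nitrogen. They also leave open what a chain ending in an amine would do there.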